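From butoxy to isobutoxy on the shared core

A few compounds are considered here, and "the series" means these few. Any claim that something is new, unique, unknown or untested is made for them only; others in the source may bear on it.

In a functional assay on NUGC-3 cells (Homo sapiens) for antiproliferative activity, read by sulforhodamine B assay (on this read-out lower numbers stand for stronger inhibition of growth and higher numbers for weaker inhibition of growth), compound 3 `CCCCOc1cccc(O)c1C(=O)/C=C/c1ccc(O)cc1` gives > 30000 nM, which is a limit and not a number. Compound 3 therefore stands at the limit of > 30000 nM in this assay, at which 2 of the 3 values shown sit. Compound 1 `O=C(/C=C/c1ccc(O)cc1)c1c(O)cccc1OCC1CCCCC1` gives > 30000 nM, which is also a limit. Compound 2 `O=C(/C=C/c1ccc(O)cc1)c1c(O)cccc1OCC1CCCC1` alone gives a number, 2140 nM.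

Compound 4 `CC(C)COc1cccc(O)c1C(=O)/C=C/c1ccc(O)cc1` differs from compound 3 by isopropyl in place of propyl on a saturated chain carbon bound to an oxygen on an aromatic ring.

Two measured steps at this place show how much the group can matter: an at least 14-fold lower number from compound 1 to compound 2 (1.14 log units; beyond the scatter), and an at least 14-fold higher number from compound 2 to compound 3 (1.14 log units; beyond the scatter). Both are large. The remaining step, a step that the two limits leave unreadable from compound 1 to compound 3, gives no size. Compound 1 is branched there yet sits at its limit, so branching alone does not secure a number.

A step towards a lower number is expected, of uncertain size, and a result at the limit remains quite possible. The expected step is an at least 2.0-fold lower number from compound 3 to compound 4 (0.30 log units; that floor lies within the scatter). The estimate for compound 4 is 15000 nM, with an expected range of 3000 nM to 30000 nM.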

Compound 4, concentration for 50% growth inhibition: 2980 nM
The estimate for compound 4 lay 5.0-fold (0.70 log units) above the measured number; the whole stated range lies above it.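

The butoxy to isobutoxy change alone is enough to turn a limit into a readable number in this assay, with an at least 10-fold lower number from compound 3 to compound 4 (1.00 log units; beyond the scatter). The isopropyl and cyclopentyl groups at this place cannot be told apart, with a 1.4-fold higher number from compound 2 to compound 4 (0.14 log units; within the scatter). Cyclohexyl at the same place stands apart, with an at least 10-fold lower number from compound 1 to compound 4 (1.00 log units; beyond the scatter), so branching goes with a readable number for the isopropyl and cyclopentyl groups, while the cyclohexyl group goes against any rule based on branching alone.

From the compounds shown here alone, the step between the two compounds held at a limit cannot be read, and each step that starts or ends at a limit gives only a floor: the limit of > 30000 nM in this assay, at which 2 of the 4 values shown sit. Whether a longer branched chain or an amine on the chain keeps a readable number stays open.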